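The compounds below may be only part of what the source reports. "The series", "measured", "known", "first", "only" and "open" are said of these compounds alone.

Compound 1 `CC(C(=O)NCc1ccc(C(F)(F)F)nc1Cl)c1ccc(NS(C)(=O)=O)c(F)c1` and compound 2 `CC(C(=O)NCc1ccc(C(F)(F)F)nc1Br)c1ccc(NS(C)(=O)=O)c(F)c1` share one core. In an assay on CHO cells for antagonist activity at transient receptor potential cation channel subfamily V member 1 (Homo sapiens), read by FLIPR and calcium flux (a higher number here means a weaker inhibitor, a lower number a stronger inhibitor), compound 1 gives 0.2 nM, while compound 2 gives 169 nM, the highest of the two numbers measured. Within the data shown here, the single measured step, an 850-fold higher number from compound 1 to compound 2 (2.93 log units; beyond the scatter), is the only one that bears on compound 3 `Cc1nc(C(F)(F)F)ccc1CNC(=O)C(C)c1ccc(NS(C)(=O)=O)c(F)c1`, where (methyl in place of bromo on an aromatic carbon). Among the measured compounds shown here, with only this one step as a guide, a return toward the number of compound 1 is expected, though with wide uncertainty. For compound 3 the expected value in this assay is 5 nM, within 0.3 nM to 100 nM. That estimate amounts to a 34-fold lower number from compound 2 to compound 3 (1.53 log units; beyond the scatter).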

Compound 3, inhibition constant: 387 nM
Compound 3: the middle estimate sits 77-fold (1.89 log units) below what was measured; the measured number lies above the stated range.
By their numbers in this assay, from the lowest: compound 1; then compound 2; then compound 3.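

On the carbon next to the ring nitrogen, methyl does not bring the number back toward that of chloro: this assay shows a 2.3-fold higher number from compound 2 to compound 3 (0.36 log units; beyond the scatter) and a 1900-fold higher number from compound 1 to compound 3 (3.29 log units; beyond the scatter). The large loss is therefore not confined to bromo, and among these three compounds only the chloro compound, compound 1, has a sub-nanomolar number. Nothing measured here accounts for this difference. The compounds shown leave open whether fluoro, methoxy, an amine or plain hydrogen at this position would keep a number near that of compound 1 or whether chloro stands alone.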